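This account rests on a few compounds, and the source may have more. Where it says the series, first, only, none or still open, it means among the compounds named here.

Measured in an ADME assay on microsomes from liver (Mus musculus) for metabolic stability, read by LC-MS, using NADPH, with a stated time of 10 min, tested at 0.5 uM; on this read-out higher numbers stand for a more stable compound and lower numbers for a less stable compound:
Compound 1 (`COC(=O)Nc1cc(-c2cc(Cl)c(OC[C@@](C)(N)CC(C)C)cn2)ccn1`) : 87%
Compound 2 (`CC(C)C[C@](C)(N)COc1cnc(-c2ccnc(Cl)c2)cc1C(F)F`) : 93%

In this assay compound 2 stands at 93%, and compound 1 lies within the usual scatter of it at 87%. For the measured compounds named here, the two compounds differ in more than one place, so no measured step isolates a single change. The next compound to be tested is compound 3 (`CC(C)C[C@](C)(N)COc1cnc(-c2ccnc(Cl)c2)cc1Cl`), which carries chloro in place of difluoromethyl on an aromatic carbon, opposite the ring nitrogen, compared with compound 2 (chloro in place of difluoromethyl on an aromatic carbon). Compound 1 also has chloro in that place, and it gives 87%. On that basis, no change beyond the scatter is expected in this assay, and any small shift would more likely be downward. The expected change is a number 3 percentage points lower from compound 2 to compound 3 (within the scatter). Compound 3 is estimated at 90%, with an expected range from 78% to 98%.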

Compound 3, percent of the compound remaining: 92%
Beside the measured number, compound 3's estimate is 2 percentage points below it, and the stated range covers the measured number.
By their numbers in this assay, from the lowest: compounds 1, 3 and 2 (each within the scatter of the next).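

In this assay, for the compounds shown here, chloro in place of difluoromethyl on the aromatic carbon opposite the ring nitrogen gives the first single-change step at this position (a number 1 percentage points lower from compound 2 to compound 3 (within the scatter)), so the read-out does not separate these two groups. A second change, chloro in place of (methoxycarbonyl)amino on an aromatic carbon, also gives a step that the read-out does not resolve (a number 5 percentage points higher from compound 1 to compound 3 (within the scatter)). No available evidence bears on either step.

The compounds shown leave open whether any group at this position would give a step beyond the scatter, since only chloro and difluoromethyl are compared there. A methoxy group, a nitrile or a carboxylic acid on this aromatic carbon would test that, and the result for these two groups cannot be extended to them.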